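Nitrate-bearing cinnamate esters: effect of ring methylation

The source may hold more compounds than are shown below. What is called first, only, known or untested is meant among the compounds shown, and "the series" means these compounds.

Measured compounds:
compound 1 `O=C(/C=C/c1ccc(OCCCCCO[N+](=O)[O-])c(O)c1)OCCCCCO[N+](=O)[O-]`, > 50000 nM
compound 2 `O=C(/C=C/c1ccc(OCCCCO[N+](=O)[O-])c(O)c1)OCCCCO[N+](=O)[O-]`, > 50000 nM
compound 3 `COc1cc(/C=C/C(=O)OCCCCCO[N+](=O)[O-])ccc1OCCCCCO[N+](=O)[O-]`, > 50000 nM

All three measured compounds were tested in a functional assay on NCI-H460 cells (Homo sapiens) for cytotoxicity, read by resazurin assay, with a stated time of 72 h; on this read-out higher numbers stand for weaker inhibition and lower numbers for stronger inhibition. For compound 1 the result is a limit of the assay and not a number: > 50000 nM. Compound 2 likewise gives only a limit in this assay, > 50000 nM. Compound 3 also stands at a limit, > 50000 nM.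

Compound 3 arises from compound 1 by methyl in place of hydrogen on an oxygen on an aromatic ring. Because both ends sit at the limit (the limit of > 50000 nM in this assay, at which 3 of the 3 values shown sit), the step that the two limits leave unreadable from compound 1 to compound 3 cannot be read.

Compound 4 `COc1cc(/C=C/C(=O)OCCCCO[N+](=O)[O-])ccc1OCCCCO[N+](=O)[O-]` has not yet been measured. It arises from compound 2 by the same change, (methyl in place of hydrogen on an oxygen on an aromatic ring); the two places are described in identical terms. The difference between the cores of compound 2 and compound 1 is not broken down here.

Given that compound 2 sits at > 50000 nM and the earlier step is unreadable, the step that the limit leaves unreadable from compound 2 to compound 4 is expected to be small. Compound 4 is estimated at 100000 nM, between 30000 nM and 400000 nM, most likely reported as a limit again.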

Compound 4, half-maximal inhibitory concentration: > 50000 nM
Compound 4 was reported as a limit; the forecaster's own chance of this, stated with the estimate: 85%; the middle value is on the limit's open side.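

In this assay compound 4 gives only a limit of the assay, > 50000 nM. No step can be read between compound 2 and compound 4, since both ends sit at the limit: the limit of > 50000 nM in this assay, at which 4 of the 4 values shown sit.

The compounds shown leave open whether hydroxy to methoxy has any effect in this assay; none of them gives a number.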